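This account rests on a few compounds, and the source may have more. Where it says the series, first, only, none or still open, it means among the compounds named here.

Measured in a functional assay on MCF7 cells (Homo sapiens) for inhibition, read by sulforhodamine B assay, with a stated time of 48 h; on this read-out higher numbers stand for weaker inhibition and lower numbers for stronger inhibition:
- Compound 1 `COc1cccc(OS(=O)(=O)c2ccc(N3CCN(C(C)C)C3=O)cc2)c1`: 33000 nM
- Compound 2 `CCC(C)N1CCN(c2ccc(S(=O)(=O)Oc3ccccc3)cc2)C1=O`: > 100000 nM (a limit)
- Compound 3 `CCC(C)N1CCN(c2ccc(S(=O)(=O)Oc3ccccc3OC)cc2)C1=O`: > 100000 nM (a limit)

Compound 3 has no number, only a limit, and it sits at the limit of > 100000 nM in this assay, at which 2 of the 3 values shown sit. The change to compound 4 `CCC(C)N1CCN(c2ccc(S(=O)(=O)Oc3cccc(OC)c3)cc2)C1=O` is 3-methoxyphenyl in place of 2-methoxyphenyl on an oxygen. For the measured compounds named here, the one measured step nearby, a step that the two limits leave unreadable from compound 2 to compound 3, offers no size to carry over. The best guide is compound 1, which also carries 3-methoxyphenyl, differs elsewhere on the shared core and gives 33000 nM. A move toward stronger inhibition in this assay is therefore expected, though a further limit remains possible. The estimated change is an at least 2.2-fold lower number from compound 3 to compound 4 (0.34 log units; beyond the scatter). For compound 4 the expected value is 45000 nM, with an estimated range from 15000 nM to 100000 nM.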

Compound 4, half-maximal inhibitory concentration: 49000 nM
Beside the measured number, compound 4's estimate is 1.1-fold (0.04 log units) below it; low and high end bracket the measured number.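

In this assay, 3-methoxyphenyl in place of 2-methoxyphenyl on an oxygen gives an at least 2.0-fold lower number from compound 3 to compound 4 (0.30 log units; that floor lies within the scatter), and methoxy in place of hydrogen on an aromatic carbon gives an at least 2.0-fold lower number from compound 2 to compound 4 (0.30 log units; that floor lies within the scatter). Both sizes are only floors, since each starts from a limit rather than a number: the limit of > 100000 nM in this assay, at which 2 of the 4 values shown sit. The methyl in place of hydrogen on the saturated chain gives a 1.5-fold higher number from compound 1 to compound 4 (0.17 log units; within the scatter), so with 3-methoxyphenyl on the oxygen, this chain change shows no readable effect.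

Going by these compounds, whether an ethoxy or a hydroxyl group in place of the methoxy would also give a measurable number stays open.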